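Notes on carboxy in place of trifluoromethoxy

A few compounds are considered here, and "the series" means these few. Any claim that something is new, unique, unknown or untested is made for them only; others in the source may bear on it.

Values so far in a physicochemical assay for solubility, at pH 7.4 (on this read-out higher numbers stand for higher solubility and lower numbers for lower solubility), for the two measured compounds
- compound 1 `COC(=O)c1ccc(NC(=O)Nc2cc(C)nc3ccccc23)cc1` gives 1200 nM 
- compound 2 `Cc1cc(NC(=O)Nc2ccc(OC(F)(F)F)cc2)c2ccccc2n1` gives 300 nM 

Compound 2 holds the lower of the two numbers, at 300 nM in a series of only two. Compound 3 `Cc1cc(NC(=O)Nc2ccc(C(=O)O)cc2)c2ccccc2n1` has not been measured. It differs from compound 2 by carboxy in place of trifluoromethoxy on an aromatic carbon, para to a large group (carboxy in place of trifluoromethoxy on an aromatic carbon).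

Among the compounds with values here, the one measured step bearing on this is a 4.0-fold lower number from compound 1 to compound 2 (0.60 log units; beyond the scatter) and it is modest, with trifluoromethoxy entering there, the group that leaves here. Read in reverse, that step points to a higher number for compound 3 than for compound 2, although methoxycarbonyl, not carboxy, stood on its other side. Within the data shown here, no measured compound carries carboxy. A rise in this assay beyond the scatter and larger than the measured step is expected, but its size is a judgement and the range is wide. The estimate means a clear rise (a 27-fold higher number from compound 2 to compound 3 (1.43 log units; beyond the scatter)). Compound 3 is estimated at 8000 nM (expected range 1500 nM to 40000 nM).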

Compound 3, solubility: 9300 nM
Estimate against measurement, compound 3: 1.2-fold (0.07 log units) below; measured number inside the range.
By their numbers in this assay, from the lowest: compound 2; then compound 1; then compound 3.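

Three groups on the aromatic carbon para to a large group can now be ordered in this assay, with trifluoromethoxy lowest, methoxycarbonyl in the middle and carboxy highest, and every gap in that order lies beyond the scatter. Carboxy in place of trifluoromethoxy gives a 31-fold higher number from compound 2 to compound 3 (1.49 log units; beyond the scatter) and is the only large step in the series, while the smaller change of hydrogen for methyl on methoxycarbonyl still gives a 7.8-fold higher number from compound 1 to compound 3 (0.89 log units; beyond the scatter), so this position can move the number much further than the first pair showed, and the ester and the free carboxy do not read alike. Nothing measured on these compounds accounts for the order of the three groups.

As far as these compounds go, whether a primary amide, a tetrazole or an amine on the same aromatic carbon would reach the number of compound 3 remains open, as does whether carboxy on a longer chain, such as carboxymethyl, would keep it. The three compounds also share the rest of the core unchanged, so they do not show whether the same order holds when another part of the structure carries a different group.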